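Ethynyl in place of thiophen-3-yl in the series

A few compounds are considered here, and "the series" means these few. Any claim that something is new, unique, unknown or untested is made for them only; others in the source may bear on it.

Two compounds of this series have been run in a functional assay on KYSE-70 cells for antiproliferative activity against KYSE-70 cell line (Homo sapiens), read by MTT assay, with a stated time of 72 h; on this read-out higher numbers stand for weaker inhibition and lower numbers for stronger inhibition. Compound 1 `O=C(Nc1ccc(Cl)cc1)c1cc(=O)[nH]c2cc(Br)ccc12` reaches only a limit of the assay: in this assay compound 1 gives > 20000 nM. Among the measured compounds shown here, compound 2 `O=C(Nc1cccc(F)c1)c1cc(=O)[nH]c2cc(-c3ccsc3)ccc12` is the only compound with a measured number: in this assay compound 2 gives 5100 nM. For the measured compounds named here, since one of the two values sits at the limit (the limit of > 20000 nM in this assay, at which 1 of the 2 values shown sits), compound 2 stands as the single point of comparison.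

Compound 3 `C#Cc1ccc2c(C(=O)Nc3cccc(F)c3)cc(=O)[nH]c2c1` is not yet measured. It differs from compound 2 in one place: ethynyl in place of thiophen-3-yl on an aromatic carbon. Going by the values given here, no step between two measured compounds is on record, so the weight of this change is untested. Compound 1, which carries no thiophen-3-yl group, gives only the limit in this assay. The step of a 1.8-fold higher number from compound 2 to compound 3 (0.25 log units; within the scatter) is therefore estimated to lie toward weaker inhibition. Compound 3 is expected near 9000 nM, within 3000 nM to 25000 nM.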

Compound 3, half-maximal inhibitory concentration: 9500 nM
Estimate against measurement, compound 3: 1.1-fold (0.02 log units) below; the measured number falls inside the stated range.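

In this assay, among the compounds shown here, this is the first step on record at this aromatic carbon: a 1.9-fold higher number from compound 2 to compound 3 (0.27 log units; within the scatter). Replacing thiophen-3-yl with ethynyl removes the five-membered aromatic ring and the sulfur, and the difference stays within the scatter, so a ring at this carbon is not required for a measured number in this pair. Both compounds give a number rather than a limit, which leaves them apart from the one value that is a limit: the limit of > 20000 nM in this assay, at which 1 of the 3 values shown sits.

Compound 1 carries bromine at this carbon but differs from compound 2 in more than one place, so the contribution of bromine remains unresolved. Also open, as far as these compounds go, is whether an amine, a carboxylic acid or a longer chain such as propyl at this carbon would move the number beyond the scatter.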